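Carbamoyl to sulfamoyl swap across two cores

The source may hold more compounds than are shown below. What is called first, only, known or untested is meant among the compounds shown, and "the series" means these compounds.

Compound 1 `COc1ccc(-c2ccnc(Nc3ccc(C(N)=O)cc3)n2)cc1` and compound 2 `COc1ccc(-c2ccnc(Nc3ccc(S(N)(=O)=O)cc3)n2)cc1` share one core; compound 2 differs from compound 1 by sulfamoyl in place of carbamoyl on an aromatic carbon. In an ADME assay on Vero cells (Chlorocebus sabaeus) for cytotoxicity, read by MTT assay, with a stated time of 72 h (a lower number here means a stronger inhibitor, a higher number a weaker inhibitor), compound 1 gives 5400 nM and compound 2 gives 2400 nM, so that a 2.3-fold lower number from compound 1 to compound 2 (0.35 log units; beyond the scatter).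

Compound 3 `CS(=O)(=O)c1ccc(-c2ccnc(Nc3cccc(C(N)=O)c3)n2)cc1` sits on a second core; the difference between the two cores is not broken down here. In this assay compound 3 gives 37900 nM, the highest of the three numbers.

Compound 4 `CS(=O)(=O)c1ccc(-c2ccnc(Nc3cccc(S(N)(=O)=O)c3)n2)cc1` is not yet measured. It differs from compound 3 by sulfamoyl in place of carbamoyl on an aromatic carbon. The place is not identical to the earlier pair: in compound 4 the group stands meta to a large group, in compound 2 para to a large group, so this is the same kind of change, not the same change.

For compound 4 the step expected in this assay is a 2.1-fold lower number from compound 3 to compound 4 (0.32 log units; beyond the scatter), set beside the earlier one because a 2.3-fold lower number from compound 1 to compound 2 (0.35 log units; beyond the scatter), with the different core and place adding uncertainty. For compound 4 the expected value in this assay is 18000 nM, within 7000 nM to 45000 nM.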

Compound 4, half-maximal inhibitory concentration: > 100000 nM
Compound 4: no number, only a limit (the forecaster's own chance of this, stated with the estimate: 20%); middle value at least 5.5-fold (0.74 log units) away from the limit.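

In this assay compound 4 gives > 100000 nM, which is a limit of the assay and not a number. The swap of carbamoyl for sulfamoyl gives an at least 2.6-fold higher number from compound 3 to compound 4 (0.42 log units; beyond the scatter), so in this series the change does not carry from one core to the other in either direction or size: the same change on two cores in this assay, a 2.3-fold lower number (0.35 log units; beyond the scatter) from compound 1 to compound 2 and an at least 2.6-fold higher number (0.42 log units; beyond the scatter) from compound 3 to compound 4, at least 5.9-fold (0.77 log units) apart, beyond the scatter of two such steps. This does not show how large the step truly is, nor whether the core or the place of the group sets the two pairs apart, and the reading rests on a single limit: the limit of > 100000 nM in this assay, at which 1 of the 4 values shown sits.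

The compounds shown leave open whether a carboxylic acid or an amine in the same place would follow the step of either pair. Also open, from the compounds shown here alone, is the size of the sulfamoyl step with the place held constant and only the core changing.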